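The compounds below may be only part of what the source reports. "The series", "measured", "known", "first", "only" and "open" are said of these compounds alone.

Measured so far in an assay on membranes from brain for binding affinity to Monoglyceride lipase (Mus musculus), read by fluorescence, with stated times of 1 h and 30 min; a lower number here means a stronger inhibitor, a higher number a weaker inhibitor:
compound 1 `Cc1cnn(C(=O)N(C)CCN(C)Cc2ccc(OCc3ccccc3)cc2)c1`: 1200 nM
compound 2 `O=C(NCc1ccc(OC(c2ccccc2)c2ccccc2)cc1)n1cccn1`: > 100000 nM, a limit of the assay rather than a number
compound 3 `Cc1cnn(C(=O)N2CCN(C(c3ccc(OCc4ccccc4)cc3)c3ccc(OCc4ccccc4)cc3)CC2)c1`: 2100 nM

Compound 2 sits at the limit of > 100000 nM in this assay, at which 1 of the 3 values shown sits; no number is known for it. Of the two numbers, compound 3 holds the higher one, but its gap to compound 1 lies within the scatter, so the two cannot be told apart. Compound 4 `N#Cc1cnn(C(=O)N2CCN(C(c3ccc(OCc4ccccc4)cc3)c3ccc(OCc4ccccc4)cc3)CC2)c1` differs from compound 3 by cyano in place of methyl on an aromatic carbon. Among the measured compounds shown here, no measured pair shows such a change. The expectation for compound 4 is a modest move to a lower number, a 3.0-fold lower number from compound 3 to compound 4 (0.48 log units; beyond the scatter), of a size that may still border the scatter. Compound 4 is therefore estimated at 700 nM, within 150 nM to 3000 nM.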

Compound 4, half-maximal inhibitory concentration: 20 nM
The estimate for compound 4 lay 35-fold (1.54 log units) above the measured number; measured number outside the range, below it.
By their numbers in this assay, from the lowest: compound 4; then compounds 1 and 3 (each within the scatter of the next). At a limit, above all of these: compound 2.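

Going from 4-methyl-1H-pyrazol-1-yl to 4-cyano-1H-pyrazol-1-yl gives a 110-fold lower number from compound 3 to compound 4 (2.02 log units; beyond the scatter) with the rest of the structure unchanged. This first one-place pair in the series marks this aromatic carbon as a site where a single small exchange moves the number strongly, which compounds 1, 2 and 3 could not show. Nothing measured here accounts for the size of the step.

Still open, as far as these compounds go, is whether the step is specific to cyano or would also appear with a chlorine atom, an amide or a carboxylic acid on that carbon. Also open, from the compounds shown here alone, is whether cyano gives a similar step on the core of compound 1.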